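The compounds below may be only part of what the source reports. "The series", "measured", "known", "first", "only" and "open" are said of these compounds alone.

The shared core, seen in compound 1 `O=c1[nH]cnc2c1c(-c1cccs1)cn2[C@@H]1O[C@H](CO)[C@@H](O)[C@H]1O` and compound 2 `O=c1[nH]cnc2c1c(-c1ccsc1)cn2[C@@H]1O[C@H](CO)[C@@H](O)[C@H]1O`, carries a varied aromatic group on one aromatic carbon. In a functional assay on CEM-DNR-bulk cells (Homo sapiens), read by MTT assay, with a stated time of 72 h (on this read-out lower numbers stand for stronger inhibition and higher numbers for weaker inhibition), compound 1 gives only a limit of the assay, > 20000 nM. In this assay compound 2 likewise returns only a limit, > 20000 nM. Among the compounds with values here, the single measured step, a step that the two limits leave unreadable from compound 1 to compound 2, cannot be read, the evidence amounting to the limit of > 20000 nM in this assay, at which 2 of the 2 values shown sit. Compound 2 thus stands at the limit, with no number to rank it against compound 1.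

Compound 3 `O=c1[nH]cnc2c1c(-c1ccccc1)cn2[C@@H]1O[C@H](CO)[C@@H](O)[C@H]1O` differs from compound 2 by phenyl in place of thiophen-3-yl on an aromatic carbon. Within the data shown here, no measured step bears directly on this change; the only step available is the unreadable one from thiophen-2-yl to thiophen-3-yl, so neither size nor direction can be taken from it. With both shown values sitting at the limit and nothing readable between them, compound 3 is expected to return a limit as well in this assay. The estimate for compound 3 is 30000 nM, in the range 8000 nM to 120000 nM. The step this estimate means, a step that the limit leaves unreadable from compound 2 to compound 3, is expected to lie within the scatter.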

Compound 3, half-maximal inhibitory concentration: > 20000 nM
Compound 3: only a limit was reported; the forecaster's own chance of this, stated with the estimate: 85%; the middle value lies beyond the limit too.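

Compound 3 returns only a limit in this assay, > 20000 nM. No step among compound 1, compound 2 and compound 3 can be read, the whole series resting on one limit: the limit of > 20000 nM in this assay, at which 3 of the 3 values shown sit.

Still open, going by these compounds, is whether thiophen-2-yl, thiophen-3-yl and phenyl differ at all in inhibition, and which change to the shared core would give a readable number.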